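The compounds below may be only part of what the source reports. "The series", "measured", "known", "first", "only" and "open" are said of these compounds alone.

Measured so far:
Compound 1 `COc1ccc(/C=C2\CCC/C(=C\c3cccc(OC)c3OC)C2=O)cc1OC` gives 14400 nM.
Compound 2 `COc1cc(/C=C2\CCC/C(=C\c3cccc(OC)c3OC)C2=O)ccc1O` reaches only a limit of the assay, > 20000 nM.
Compound 3 `COc1cc(/C=C2\CCC/C(=C\c3ccc(OC)c(OC)c3)C2=O)ccc1O` gives 10300 nM.

All three numbers come from a functional assay on A549 cells (Homo sapiens) for cytotoxicity, read by MTT assay, with a stated time of 72 h; on this read-out lower numbers stand for stronger inhibition and higher numbers for weaker inhibition. Compound 1 and compound 2 differ in one place: hydrogen in place of methyl on an oxygen on an aromatic ring. The step measured for that change is an at least 1.3-fold higher number from compound 1 to compound 2 (0.14 log units; that floor lies within the scatter), and its floor rests on (the limit of > 20000 nM in this assay, at which 1 of the 3 values shown sits). The difference between the cores of compound 1 and compound 3 is not broken down here; their two numbers lie close together. Compound 4 `COc1ccc(/C=C2\CCC/C(=C\c3ccc(O)c(O)c3)C2=O)cc1OC` is not yet measured. It differs from compound 3 by the change already seen, (hydrogen in place of methyl on an oxygen on an aromatic ring), and the place of the change reads the same for both pairs, so this is the same change. In this assay compound 4 is expected to move by a 1.6-fold higher number from compound 3 to compound 4 (0.19 log units; within the scatter), an expectation that rests on the earlier step of an at least 1.3-fold higher number from compound 1 to compound 2 (0.14 log units; that floor lies within the scatter), which went toward a higher number. The estimate for compound 4 is 16000 nM, between 8000 nM and 40000 nM, with a real chance that only a limit is reported again.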

Compound 4, half-maximal inhibitory concentration: > 20000 nM
Compound 4 gave a limit, no number (the forecaster's own chance of this, stated with the estimate: 30%); at least 1.2-fold (0.09 log units) between middle value and limit.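

In this assay, compound 4 gives > 20000 nM, which is a limit and not a number, so replacing methoxy with hydroxy can be stated only as a floor: an at least 1.9-fold higher number from compound 3 to compound 4 (0.28 log units; that floor lies within the scatter). Neither this floor nor the earlier one lies beyond the scatter, so the series does not show a real loss on either core, although nothing in the two steps contradicts a shift in the same direction, and the size of the change cannot be carried from one core to the other: the same change on two cores in this assay, an at least 1.3-fold higher number (0.14 log units; that floor lies within the scatter) from compound 1 to compound 2 and an at least 1.9-fold higher number (0.28 log units; that floor lies within the scatter) from compound 3 to compound 4; the limit leaves it open whether they differ. The comparison is restricted further by how many of the compounds stop at the same limit: the limit of > 20000 nM in this assay, at which 2 of the 4 values shown sit.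

The compounds shown leave open how large the step really is on each core, since compound 2 and compound 4 give no number to compare. They also leave open what would happen if an amine or a longer chain such as ethoxy stood in place of the methoxy group on the aromatic ring.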